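From Ethylpiperazinylmethyl to Methylcarbamoyl: an Expected Solubility

The compounds below may be only part of what the source reports. "The series", "measured", "known", "first", "only" and "open" are said of these compounds alone.

Compound 1 `CCN1CCN(C[C@H]2CN(c3ccc(-n4cc(-c5ccccn5)cn4)c(F)c3)C(=O)O2)CC1` gives 706000 nM in a physicochemical assay for solubility, read by HPLC, with a stated time of 24 h; on this read-out higher numbers stand for higher solubility and lower numbers for lower solubility.
Compound 2 `O=C1O[C@@H](CSc2cccs2)CN1c1ccc(-n2cc(-c3ccccn3)cn2)c(F)c1` gives 8500 nM in this assay.
Compound 3 `O=C1O[C@@H](Cn2ccnn2)CN1c1ccc(-n2cc(-c3ccccn3)cn2)c(F)c1` gives 247000 nM in this assay.

Compound 1 stands highest of the three measured compounds in this assay; compound 3 is its nearest neighbour and compound 2 the furthest. Compound 4 `CNC(=O)[C@H]1CN(c2ccc(-n3cc(-c4ccccn4)cn3)c(F)c2)C(=O)O1` has not been measured yet. It differs from compound 1 in one place: methylcarbamoyl in place of (4-ethylpiperazin-1-yl)methyl on a saturated ring carbon.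

Among the compounds with values here, two measured steps bear on this change, both starting from compound 1 and both replacing the 4-ethylpiperazin-1-yl group. The step of an 83-fold lower number from compound 1 to compound 2 (1.92 log units; beyond the scatter) was large, while the step of a 2.9-fold lower number from compound 1 to compound 3 (0.46 log units; beyond the scatter) was modest. In each case removing that group lowered the number, so a drop is expected for compound 4 as well. The methylcarbamoyl group that enters carries one hydrogen-bond donor and one acceptor, which puts it closer to the pattern of compound 3 than compound 2, so a modest rather than a large step is the expectation.

Compound 4 is therefore estimated at 200000 nM, between 60000 nM and 600000 nM, which means an expected step of a 3.5-fold lower number from compound 1 to compound 4 (0.55 log units; beyond the scatter).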

Compound 4, solubility: 26200 nM
Compound 4: middle estimate off by 7.6-fold (0.88 log units), on the high side; measured number outside the range, below it.
By their numbers in this assay, from the lowest: compound 2; then compound 4; then compound 3; then compound 1.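

On this saturated ring carbon, methylcarbamoyl in place of (4-ethylpiperazin-1-yl)methyl gave a large step in this assay (a 27-fold lower number from compound 1 to compound 4 (1.43 log units; beyond the scatter)). Compound 4 lands among the earlier replacements, with modest steps on either side (a 9.4-fold lower number from compound 3 to compound 4 (0.97 log units; beyond the scatter); a 3.1-fold higher number from compound 2 to compound 4 (0.49 log units; beyond the scatter)). Compounds 1, 2 and 3 all keep a methyl link on this ring carbon and differ only in the group at its end, whereas the carbonyl of methylcarbamoyl sits directly on the ring carbon, so this change alters the link as well as the end group.

The compounds shown do not separate those two changes, and a carboxylic acid or a longer chain ending in a primary amine on the same ring carbon would test more of this position. Nothing here gives a measured reason for the size of any of these steps.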